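Thromboxane receptor sulfonamides: predicting a dichlorophenyl analogue

This account rests on a few compounds, and the source may have more. Where it says the series, first, only, none or still open, it means among the compounds named here.

Compound 1 `O=C(O)CC/C=C\C[C@H]1[C@H](F)CC[C@@H]1NS(=O)(=O)c1ccc(Cl)c(Cl)c1`: 1700 nM
Compound 2 `O=C(O)CCC/C=C\C[C@H]1[C@H](F)CC[C@@H]1NS(=O)(=O)c1ccccc1[N+](=O)[O-]`: 1800 nM
Compound 3 `O=C(O)CC/C=C\C[C@H]1[C@H](F)CC[C@@H]1NS(=O)(=O)c1ccccc1[N+](=O)[O-]`: 560 nM

Of the compounds shown here, three have been measured in a functional assay on a cell-free system (plasma) for inhibition of thromboxane A2 receptor (Homo sapiens), read by turbidimetry; on this read-out higher numbers stand for weaker inhibition and lower numbers for stronger inhibition. Compound 3 gives 560 nM, and the change 3,4-dichlorophenyl in place of 2-nitrophenyl on a sulfonyl sulfur makes the step of a 3.0-fold higher number from compound 3 to compound 1 (0.48 log units; beyond the scatter). Compound 1 and compound 2 lie within the scatter of each other, so no order between them is claimed; a 3.2-fold lower number from compound 2 to compound 3 (0.51 log units; beyond the scatter) carries the core difference (carboxymethyl in place of carboxy on a saturated chain carbon, two bonds along the chain from a double-bonded chain carbon).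

Compound 4 `O=C(O)CCC/C=C\C[C@H]1[C@H](F)CC[C@@H]1NS(=O)(=O)c1ccc(Cl)c(Cl)c1` is not yet measured. It differs from compound 2 by 3,4-dichlorophenyl in place of 2-nitrophenyl on a sulfonyl sulfur, the same change as from compound 3 to compound 1, at a place described in the same words. Resting on that single measured step, compound 4 is expected to give 5000 nM in this assay, a step of a 2.8-fold higher number from compound 2 to compound 4 (0.44 log units; beyond the scatter) from compound 2, within 2000 nM to 12000 nM.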

Compound 4, half-maximal inhibitory concentration: 630 nM
The estimate for compound 4 lay 7.9-fold (0.90 log units) above the measured number; the measured number lies below the stated range.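

In this assay, the change to 3,4-dichlorophenyl did not carry from one core to the other: on the longer chain it gives a 2.9-fold lower number from compound 2 to compound 4 (0.46 log units; beyond the scatter), opposite in direction to the earlier step: the same change on two cores in this assay, a 3.0-fold higher number (0.48 log units; beyond the scatter) from compound 3 to compound 1 and a 2.9-fold lower number (0.46 log units; beyond the scatter) from compound 2 to compound 4, 8.7-fold (0.94 log units) apart, beyond the scatter of two such steps. The chain change reverses as well, with a 2.7-fold lower number from compound 1 to compound 4 (0.43 log units; beyond the scatter): the same change on two cores in this assay, a 3.2-fold lower number (0.51 log units; beyond the scatter) from compound 2 to compound 3 and a 2.7-fold higher number (0.43 log units; beyond the scatter) from compound 4 to compound 1, 8.7-fold (0.94 log units) apart, beyond the scatter of two such steps. Within these four compounds, the outcome of each change therefore depends on the other, but the data do not show why, nor whether this extends beyond these two aryl groups and two chain lengths.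

On these data alone, whether the reversal would persist with a phenyl without substituents on the sulfonyl sulfur remains open. So does the result of a still longer chain ending in the carboxylic acid.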